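Gem-dimethyl on the hydroxycyclohexyl ring of a kinase inhibitor

The compounds below may be only part of what the source reports. "The series", "measured", "known", "first", "only" and "open" are said of these compounds alone.

Measured compounds:
- Compound 1 `N#Cc1cnc(NCc2cnccc2C(F)(F)F)cc1N[C@H]1CC[C@@H](O)CC1` gives 100 nM in an assay on isolated protein for inhibition of protein kinase C theta type (Homo sapiens), read by TR-FRET, with a stated time of 2 h; on this read-out lower numbers stand for stronger inhibition and higher numbers for weaker inhibition.
- Compound 2 `CN(C)C(=O)[C@H]1CC[C@@H](Nc2cc(NCc3cnccc3C(F)(F)F)ncc2C#N)CC1` gives 38 nM in this assay.

Compound 1 has the highest number of the two measured in this assay; the nearest is compound 2, with a 2.6-fold lower number from compound 1 to compound 2 (0.42 log units; beyond the scatter).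

Compound 3 `CC1(C)C[C@H](Nc2cc(NCc3cnccc3C(F)(F)F)ncc2C#N)CC[C@@H]1O` differs from compound 1 in one place: 4-hydroxy-3,3-dimethylcyclohexyl in place of 4-hydroxycyclohexyl on a nitrogen on an aromatic ring.

Going by the values given here, no measured step matches this change. Among the compounds with values here, the only step known, from compound 1 to compound 2, replaces the hydroxy group itself and says nothing about adding two methyl groups to a carbon of the same saturated ring while the hydroxy stays. With the hydroxy group and the rest of the shared core kept, the expectation for compound 3 is a number close to that of compound 1, with no step beyond the scatter in either direction. Compound 3 is therefore estimated at 85 nM, in the range 30 nM to 250 nM, an expected step of a 1.2-fold lower number from compound 1 to compound 3 (0.07 log units; within the scatter).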

Compound 3, half-maximal inhibitory concentration: 7 nM
Estimate against measurement, compound 3: 12-fold (1.08 log units) above; the whole stated range lies above it.
By their numbers in this assay, from the lowest: compound 3; then compound 2; then compound 1.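

In this assay, the saturated ring responds strongly to a change that leaves the hydroxy group in place: adding the two methyl groups gives a 14-fold lower number from compound 1 to compound 3 (1.15 log units; beyond the scatter). The earlier comparison, a 2.6-fold lower number from compound 1 to compound 2 (0.42 log units; beyond the scatter), changed only the group at the hydroxy position, so it could not show whether other carbons of this ring affect the read-out. Nothing available here explains the size of this step.

On these data alone, it remains open whether a single methyl group would have a similar effect, or whether a larger pair of groups, such as two ethyl groups, would go further. It is also unknown whether the two methyl groups would give a similar step with the dimethylcarbamoyl group of compound 2, or with an amine, in place of the hydroxy group.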